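Notes on replacing bromo with methyl in compound 2

This account rests on a few compounds, and the source may have more. Where it says the series, first, only, none or still open, it means among the compounds named here.

Measured in a functional assay on SiHa cells (Homo sapiens) for inhibition, read by CCK-8 assay, with a stated time of 72 h, tested at 1 uM; on this read-out higher numbers stand for more inhibition of growth at the one concentration tested and lower numbers for less inhibition of growth:
compound 1 `CN(C)C(=O)c1cc2cnc(Nc3ccc(NC(=O)C4(C(=O)Nc5cccc(Cl)c5)CC4)cc3)nc2n1C1CCCC1`: 16.2%
compound 2 `CN(C)C(=O)c1cc2cnc(Nc3ccc(NC(=O)C4(C(=O)Nc5ccc(Br)cc5)CC4)cc3)nc2n1C1CCCC1`: 23.2%

Compound 2, at 23.2%, lies within the scatter of compound 1, so neither stands apart on these numbers. Compound 3 `Cc1ccc(NC(=O)C2(C(=O)Nc3ccc(Nc4ncc5cc(C(=O)N(C)C)n(C6CCCC6)c5n4)cc3)CC2)cc1` follows from compound 2 through (methyl in place of bromo on an aromatic carbon), with methyl in place of bromo para to a large group. Within the data shown here, one measured step bears on this change, and only indirectly: a number 7 percentage points higher from compound 1 to compound 2 (within the scatter). Among the measured compounds shown here, it alters the same aromatic group but involves no methyl, and no methyl compound has been measured. No step beyond the scatter is therefore expected in this assay, and no direction can be assigned with confidence. The expected step is a number 3.2 percentage points lower from compound 2 to compound 3 (within the scatter). For compound 3, the estimate is 20%, with an expected range of 8% to 34%.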

Compound 3, percent growth inhibition at one concentration: 37%
Beside the measured number, compound 3's estimate is 17 percentage points below it, outside the stated range (above it).
By their numbers in this assay, from the lowest: compounds 1 and 2 (each within the scatter of the next); then compound 3.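

In this assay methyl in place of bromo on the aromatic carbon para to a large group gives a number 13.8 percentage points higher from compound 2 to compound 3 (beyond the scatter) and so shows that the group at this position can move the read-out, which the earlier pair of compounds, lying within the scatter of each other, could not show. Compound 3 also stands apart from the other earlier compound, with 4-methylphenyl in place of 3-chlorophenyl giving a number 20.8 percentage points higher from compound 1 to compound 3 (beyond the scatter) as a second modest step. Nothing available explains why methyl gives more inhibition of growth here than bromo.

Among these compounds, only two groups have been compared at this position, so a single step cannot show a trend across substituents. On these data alone, whether an ethyl group, a methoxy group or an amine there would match or exceed methyl remains open.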